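The compounds below may be only part of what the source reports. "The series", "measured", "known", "first", "only" and "open" are said of these compounds alone.

Working notes on the series.

Among the measured compounds shown here, compound 1 `O=C(/C=C/c1cc(F)cc(F)c1O)c1ccccc1` sits at the top of the two numbers so far: in a functional assay on MCF7 cells (Homo sapiens) for antiproliferative activity, read by sulforhodamine B assay, with a stated time of 72 h, tested at 10 uM (a lower number here means a stronger effect, a higher number a weaker effect of the compound at the concentration tested), compound 1 gives 110%. Compound 2 `COc1cc(Br)cc(/C=C/C(=O)c2ccc(C)cc2)c1O` carries a methyl on its ketone-side ring together with different substituents on the other ring, and in this assay compound 2 gives 96.8%, a gap beyond the scatter, though the two differ in several places at once.

Compound 3 `Cc1ccc(C(=O)/C=C/c2cc(F)cc(F)c2O)cc1` is not yet measured. It differs from compound 1 in one place: methyl in place of hydrogen on an aromatic carbon.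

For the measured compounds named here, with no single-change step measured, the expected step of a number 8 percentage points lower from compound 1 to compound 3 (within the scatter) is small, at most a modest move downward, likely within the scatter. Compound 3 is therefore expected to give about 102% in this assay, estimated between 85% and 118%.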

Compound 3, a percentage reported as activity, at one concentration (the size of the read-out at that concentration, not a potency): 33.9%
Compound 3: middle estimate off by 68.1 percentage points, on the high side; measured number outside the range, below it.
By their numbers in this assay, from the lowest: compound 3; then compound 2; then compound 1.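

Among the compounds shown here, the first one-place step shows that this position is far from silent: in this assay, methyl in place of hydrogen on an aromatic carbon, para to a large group, gives a number 76.1 percentage points lower from compound 1 to compound 3 (beyond the scatter) on the core of compound 1. A single added carbon is therefore enough to carry the series from the top of its numbers to the bottom. No measurement shown accounts for the size of this step.

Going by these compounds, whether ethyl, methoxy or chlorine at the same place would give a similar step remains open. So does whether the methyl step holds with other substituents on the second ring.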